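The source may report more compounds than this note shows. Statements on the series, on what has been measured and on what is new or still open speak of the compounds shown alone.

Measured compounds:
compound 1 `Oc1ccccc1CNc1ncnc2c1ncn2C1CCCCO1` — > 100000 nM
compound 2 `COc1cccc(CNc2ncnc3c2ncn3C2CCCCO2)c1O` — > 100000 nM
compound 3 `COc1ccc(CNc2ncnc3c2ncn3C2CCCCO2)cc1OC` — > 100000 nM

The three were read in an ADME assay on BJ cells (Homo sapiens) for cytotoxicity, read by MTT assay, with a stated time of 72 h; on this read-out lower numbers stand for stronger inhibition and higher numbers for weaker inhibition. In this assay compound 1 gives > 100000 nM, which is a limit of the assay and not a number. Compound 2 gives > 100000 nM, likewise a limit. Compound 3 gives > 100000 nM, also a limit. All three stand at the limit of > 100000 nM in this assay, at which 3 of the 3 values shown sit.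

From compound 1 to compound 2 the change is methoxy in place of hydrogen on an aromatic carbon. The step that the two limits leave unreadable from compound 1 to compound 2; both ends of it sit at the limit of > 100000 nM in this assay, at which 3 of the 3 values shown sit, so its size cannot be read. How compound 3 differs from compound 1 is not broken down here.

Compound 4 `COc1cc(OC)c(OC)cc1CNc1ncnc2c1ncn2C1CCCCO1` has not been measured in this assay. From compound 3 to compound 4 the change is methoxy in place of hydrogen on an aromatic carbon. This is the same kind of change as from compound 1 to compound 2, though the surroundings differ: in compound 2 the entering methoxy is ortho to a hydroxy group and meta to a large group, whereas in compound 4 it is ortho to a large group, meta to a methoxy group and para to a methoxy group.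

For compound 4 the step that the limit leaves unreadable from compound 3 to compound 4 is expected beside the earlier step, and this expectation rests on (the limit of > 100000 nM in this assay, at which 3 of the 3 values shown sit). Compound 3 itself gives > 100000 nM, a limit. Compound 4 is therefore estimated at 150000 nM, most likely again reported only as a limit.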

Compound 4, half-maximal inhibitory concentration: > 100000 nM
Compound 4 was reported as a limit (the forecaster's own chance of this, stated with the estimate: 85%); the middle value lies beyond the limit too.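

In this assay compound 4 gives > 100000 nM as a limit and not a number. No new step can be read, and the step from compound 3 to compound 4 stays without a size, because both ends sit at a limit: the limit of > 100000 nM in this assay, at which 4 of the 4 values shown sit.

The compounds shown leave open whether methoxy in place of hydrogen on an aromatic carbon changes the true value in this assay at all.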